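This account rests on a few compounds, and the source may have more. Where it says the series, first, only, none or still open, it means among the compounds named here.

Compound 2 `O=C(NCc1cn(Cc2ccc(Cl)cc2)nn1)c1cn(-c2ccccc2)nc1-c1ccc(F)cc1` stands as the lower of the two numbers in a functional assay on MIA PaCa-2 cells (Homo sapiens) for antiproliferative activity, read by sulforhodamine B assay, with a stated time of 48 h (a lower number here means a stronger inhibitor of growth, a higher number a weaker inhibitor of growth), giving 280 nM, while compound 1 `O=C(NCc1cn(Cc2ccc(Cl)cc2)nn1)c1cn(-c2ccccc2)nc1-c1ccccc1` gives 8700 nM. Among the measured compounds shown here, the only measured step, a 31-fold lower number from compound 1 to compound 2 (1.49 log units; beyond the scatter), concerns a different place from the change now considered. Compound 3 `COc1cc(Cn2cc(CNC(=O)c3cn(-c4ccccc4)nc3-c3ccc(F)cc3)nn2)cc(OC)c1` differs from compound 2 by 3,5-dimethoxyphenyl in place of 4-chlorophenyl on a saturated chain carbon bound to an aromatic nitrogen. For the measured compounds named here, no measured step bears on this change, so a step of a 1.4-fold higher number from compound 2 to compound 3 (0.15 log units; within the scatter) is expected, meaning nothing beyond the scatter, with wide uncertainty. Compound 3 is therefore estimated at 400 nM, within a range from 100 nM to 2000 nM.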

Compound 3, concentration for 50% growth inhibition: 190 nM
Compound 3: the middle estimate sits 2.1-fold (0.32 log units) above what was measured; the measured number falls inside the stated range.
By their numbers in this assay, from the lowest: compounds 3 and 2 (each within the scatter of the next); then compound 1.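

In this assay the change on this saturated chain carbon gives a 1.5-fold lower number from compound 2 to compound 3 (0.17 log units; within the scatter) and so leaves growth inhibition unchanged within the scatter. Unlike the fluoro change elsewhere on the molecule, this swap shows that 4-chlorophenyl can give way to 3,5-dimethoxyphenyl, a ring with quite different substituents, without a measurable effect. Nothing measured here explains why these two groups match. As far as these compounds go, whether an amine or a carboxylic acid at this place would shift the number stays open. So does whether the 3,5-dimethoxyphenyl result depends on the fluoro group elsewhere on the molecule.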